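Urea Replacing Cyclobutyl Amide on the Shared Core

The compounds below may be only part of what the source reports. "The series", "measured", "known", "first", "only" and "open" are said of these compounds alone.

In an assay on isolated protein for inhibition of Gonadotropin-releasing hormone receptor (Rattus norvegicus) (a higher number here means a weaker inhibitor, a lower number a stronger inhibitor), compound 3 `COc1ccc([N+](=O)[O-])cc1CSc1nc2cc(NC(=O)C3CCC3)ccc2n1C(C)C` gives 630 nM, the highest of the three numbers shown. Going by the values given here, compound 1 `CCCn1c(SCc2cc([N+](=O)[O-])ccc2OC)nc2cc(NC(=O)NC(C)(C)C)ccc21` gives 120 nM and compound 2 `COc1ccc([N+](=O)[O-])cc1CSc1nc2cc(NC(=O)NC(C)(C)C)ccc2n1Cc1ccncc1` gives 240 nM; the only single-point step among them, a 2.0-fold higher number from compound 1 to compound 2 (0.30 log units; within the scatter), concerns the group on a saturated chain carbon bound to an aromatic nitrogen and does not bear on the change considered here. Compound 4 `COc1ccc([N+](=O)[O-])cc1CSc1nc2cc(NC(=O)NC(C)C)ccc2n1C(C)C` differs from compound 3 by isopropylamino in place of cyclobutyl on a carbonyl carbon. Among the compounds with values here, no measured pair isolates this change; compounds 1 and 2, which also carry a carbamoylamino group, show lower numbers than compound 3, yet they differ from it elsewhere as well. A moderately lower number is therefore expected for compound 4, a step of a 2.1-fold lower number from compound 3 to compound 4 (0.32 log units; beyond the scatter). Compound 4 is estimated at 300 nM, with a range from 100 nM to 900 nM.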

Compound 4, half-maximal inhibitory concentration: 280 nM
Compound 4: the middle estimate sits 1.1-fold (0.03 log units) above what was measured; low and high end bracket the measured number.
By their numbers in this assay, from the lowest: compounds 1, 2 and 4 (each within the scatter of the next, the first and the last beyond it); then compound 3.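

On a carbonyl carbon whose other neighbour is an amide-type nitrogen, isopropylamino in place of cyclobutyl gives a 2.3-fold lower number from compound 3 to compound 4 (0.35 log units; beyond the scatter) in this assay, so this change now stands alone in one pair of compounds. Going by these compounds alone, the step is modest, and it is the first read directly at this position, where a carbon-only ring leaves and an open group with a hydrogen-bond donor enters. Nothing measured here explains it. Still open, from the compounds shown here alone, is whether the ring's loss or the added nitrogen matters more. A cyclobutylamino group on this carbonyl carbon would separate the two.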